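The source may report more compounds than this note shows. Statements on the series, on what has been measured and on what is new or still open speak of the compounds shown alone.

Compound 1 `CCC1CCN(c2nc(C(C)(C)C)ccc2CNC(=O)C(C)c2ccc(NS(C)(=O)=O)c(F)c2)CC1` gives 0.1 nM in an assay on cells for antagonist activity at transient receptor potential cation channel subfamily V member 1 (Homo sapiens), read by FLIPR and calcium flux, with a stated time of 6 min; on this read-out higher numbers stand for weaker inhibition and lower numbers for stronger inhibition. Compound 2 `CC(C)COc1nc(C(C)(C)C)ccc1CNC(=O)C(C)c1ccc(NS(C)(=O)=O)c(F)c1` gives 0.6 nM in this assay.

In this assay compound 2 holds the higher of the two numbers; its nearest neighbour is compound 1, separated by the step of a 6.0-fold higher number from compound 1 to compound 2 (0.78 log units; beyond the scatter). Compound 3 `CC(C(=O)NCc1ccc(C(C)(C)C)nc1OC1CCCC1)c1ccc(NS(C)(=O)=O)c(F)c1` carries the change (cyclopentyl in place of isobutyl on an oxygen on an aromatic ring). Among the compounds with values here, the only measured step, a 6.0-fold higher number from compound 1 to compound 2 (0.78 log units; beyond the scatter), exchanged the whole group on the aromatic carbon, whereas here the oxygen remains and only the alkyl on it changes, so no measured step bears directly on this exchange. A step within the scatter is therefore expected, no change at the digits printed from compound 2 to compound 3 (within the scatter). Compound 3 is estimated at 0.6 nM, with a range from 0.25 nM to 1.5 nM.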

Compound 3, inhibition constant: 1.5 nM
Compound 3: middle estimate off by 2.5-fold (0.40 log units), on the low side, within the range that was stated.
By their numbers in this assay, from the lowest: compound 1; then compound 2; then compound 3.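

With the oxygen kept, the alkyl on it still matters: a 2.5-fold higher number from compound 2 to compound 3 (0.40 log units; beyond the scatter), so cyclopentyl in place of isobutyl is enough to move the number, and not only an exchange of the whole group on the aromatic carbon. The 4-ethylpiperidin-1-yl group still gives the lowest number of the three, with a 15-fold higher number from compound 1 to compound 3 (1.18 log units; beyond the scatter). No evidence given here accounts for either step.

As far as these compounds go, it remains open how a smaller alkyl on the oxygen, such as methyl or ethyl, would read, and how an open-chain amine such as diethylamino would read on the same aromatic carbon.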